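Sulfamoyl for Nitro: Cytotoxicity Outlook for Compound 4

This account rests on a few compounds, and the source may have more. Where it says the series, first, only, none or still open, it means among the compounds named here.

Compound 1, `COc1cc2nc(SCC(=O)Nc3ccc(C(F)(F)F)cc3)nc(Nc3c(C)cc(/C=C/C#N)cc3C)c2cc1OC`: in an ADME assay on MT4 cells (Homo sapiens) for cytotoxicity, read by MTT assay, with a stated time of 5 days (a higher number here means that more compound is tolerated, a lower number that less compound is tolerated), compound 1 reaches only a limit of the assay, > 211000 nM.
Compound 2, `COc1cc2nc([S+]([O-])CC(=O)Nc3ccc(C(F)(F)F)cc3)nc(Nc3c(C)cc(/C=C/C#N)cc3C)c2cc1OC`: in this assay compound 2 gives 52200 nM.
Compound 3, `COc1cc2nc([S+]([O-])CC(=O)Nc3cccc([N+](=O)[O-])c3)nc(Nc3c(Cl)cc(/C=C/C#N)cc3Cl)c2cc1OC`: in this assay compound 3 reaches only a limit of the assay, >= 83200 nM.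

Compound 3 stands at a limit rather than at a number; it sits at the limit of >= 83200 nM in this assay, at which 1 of the 3 values shown sits. Of the other two values shown, one is also a limit, (the limit of > 211000 nM in this assay, at which 1 of the 3 values shown sits), and only compound 2 carries a plain number. Among the compounds with values here, no two measured compounds differ in a single place, so no measured step guides the next change.

Compound 4, `COc1cc2nc([S+]([O-])CC(=O)Nc3cccc(S(N)(=O)=O)c3)nc(Nc3c(Cl)cc(/C=C/C#N)cc3Cl)c2cc1OC`, differs from compound 3 in one place: sulfamoyl in place of nitro on an aromatic carbon. Within the data shown here, with no measured step for a change of this kind, the expectation in this assay is a step of no size beyond the usual scatter, in no particular direction. Compound 4 is therefore expected to tolerate roughly 100000 nM, somewhere between 40000 nM and 250000 nM. The expected step is a step that the limit leaves unreadable from compound 3 to compound 4, and a limit rather than a number is again thought likely.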

Compound 4, half-maximal cytotoxic concentration: 67800 nM
Compound 4: the middle estimate sits 1.5-fold (0.17 log units) above what was measured, and the stated range covers the measured number.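

In this assay compound 4 gives a plain number, 67800 nM, so this aromatic carbon now has a firm reading. Sulfamoyl in place of nitro gives an at least 1.2-fold lower number from compound 3 to compound 4 (0.08 log units; that floor lies within the scatter), and this floor alone does not show a change beyond the usual scatter. The true size of the step cannot be read, because compound 3 stands at a limit and not at a number: the limit of >= 83200 nM in this assay, at which 1 of the 4 values shown sits.

As far as these compounds go, whether another group on this aromatic carbon, such as an amine or a carboxylic acid, would shift the tolerated concentration remains open. From the compounds shown here alone, it is also open whether sulfamoyl in place of nitro would give a similar step on a compound with different groups elsewhere, such as compound 2.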